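The source may report more compounds than this note shows. Statements on the series, on what has been measured and on what is new or still open speak of the compounds shown alone.

In an assay on isolated protein for inhibition of thyroid hormone receptor alpha (Homo sapiens), read by fluorescence polarization (on this read-out lower numbers stand for stronger inhibition and higher numbers for weaker inhibition), compound 1 `CS(=O)(=O)c1ccc(C(=O)NCCC(=O)N2CCCCC2)cc1[N+](=O)[O-]` gives only a limit, > 60000 nM. Compound 2 `CS(=O)(=O)c1ccc(C(=O)NCCC(=O)N2CCCc3ccccc32)cc1[N+](=O)[O-]` likewise gives only a limit in this assay, > 60000 nM. Both recorded values sit at the limit of > 60000 nM in this assay, at which 2 of the 2 values shown sit. Among the measured compounds shown here, the single measured step is a step that the two limits leave unreadable from compound 1 to compound 2, whose size the two limits hide. Compound 3 `CS(=O)(=O)c1ccc(C(=O)NCCC(=O)N2CCc3ccccc32)cc1[N+](=O)[O-]` differs from compound 2 by 2,3-dihydro-1H-indol-1-yl in place of 1,2,3,4-tetrahydroquinolin-1-yl on a carbonyl carbon. For the measured compounds named here, no readable step bears on this change, and with every recorded value at the limit no size of step can be foreseen in this assay. Compound 3 is expected to stay at the limit as well, estimated at 80000 nM with a range from 30000 nM to 300000 nM. The implied step that the limit leaves unreadable from compound 2 to compound 3 is expected to be none beyond the scatter.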

Compound 3, half-maximal inhibitory concentration: > 60000 nM
Compound 3 gave a limit, no number; the forecaster's own chance of this, stated with the estimate: 85%; the middle value lies beyond the limit too.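

Among the compounds shown here, the steps among compound 1, compound 2 and compound 3 cannot be read in this assay, and no new step follows from them: the limit of > 60000 nM in this assay, at which 3 of the 3 values shown sit. The compounds shown leave open whether these three differ at all in inhibition, and what change to the shared core would give a measurable value.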